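The source may report more compounds than this note shows. Statements on the series, on what has been measured and on what is new or still open speak of the compounds shown alone.

Series so far, measured in a functional assay on A-375 cells (Homo sapiens) for activation, with a stated time of 3 days; on this read-out higher numbers stand for an effect only at larger amounts of compound and lower numbers for an effect already at smaller amounts:
- compound 1 `O=C(Nc1ccc(-c2ccccn2)cc1)C1CCCN(Cc2ccc(F)c(F)c2)C1`: 11000 nM
- compound 2 `O=C(Nc1ccc(-c2nccs2)cc1)C1CCCN(Cc2ccc(F)c(F)c2)C1`: 800 nM

For the measured compounds named here, of these two numbers, compound 2 holds the lower at 800 nM, and compound 1 is its only neighbour. Next in line is compound 3 `O=C(Nc1ccc(-c2c[nH]cn2)cc1)C1CCCN(Cc2ccc(F)c(F)c2)C1`, with 1H-imidazol-4-yl in place of 1,3-thiazol-2-yl on an aromatic carbon. Going by the values given here, one measured step bears on this, at the same place: a 14-fold lower number from compound 1 to compound 2 (1.14 log units; beyond the scatter). It was large and beyond the scatter, so the read-out clearly responds to the group here. Among the compounds with values here, the new exchange keeps a five-membered aromatic ring with 2 hetero atoms, but a hydrogen-bond donor enters, and no measured compound carries one at this place. A moderate rise in this assay is therefore expected, smaller than that single step and with wide uncertainty. The expected change is a 2.5-fold higher number from compound 2 to compound 3 (0.40 log units; beyond the scatter). Compound 3 is estimated at 2000 nM, with an expected range of 400 nM to 10000 nM.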

Compound 3, half-maximal effective concentration: 16000 nM
Compound 3: middle estimate off by 8.0-fold (0.90 log units), on the low side; measured number above the stated range.
By their numbers in this assay, from the lowest: compound 2; then compounds 1 and 3 (each within the scatter of the next).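

In this assay the exchange of 1,3-thiazol-2-yl for 1H-imidazol-4-yl is a large step (a 20-fold higher number from compound 2 to compound 3 (1.30 log units; beyond the scatter)), so keeping a five-membered aromatic ring with 2 hetero atoms at this place does not keep the low number of compound 2. For the compounds shown here, the 1H-imidazol-4-yl and pyridin-2-yl groups cannot be told apart here (a 1.5-fold higher number from compound 1 to compound 3 (0.16 log units; within the scatter)), which leaves 1,3-thiazol-2-yl as the only one of the three groups that stands apart. No measurement at hand explains this difference.

Still open, going by these compounds, is whether the sulfur atom matters, which 1,3-oxazol-2-yl or thiophen-2-yl at the same place could test. A 1-methylimidazol-4-yl group could separate the hydrogen on the ring nitrogen from the rest of the 1H-imidazol-4-yl ring.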